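Replacing the terminal amine of the urea side chain

This account rests on a few compounds, and the source may have more. Where it says the series, first, only, none or still open, it means among the compounds named here.

Among the compounds with values here, compound 2 `O=C(NCCN1CCCC1)Nc1cc2c(Nc3ccc(F)c(Cl)c3)ncnc2cc1O[C@H]1CCOC1` gives the lowest of the two numbers measured so far in a functional assay on A-431 cells (Homo sapiens) for antiproliferative activity, read by sulforhodamine B assay, with a stated time of 72 h (a higher number here means a weaker inhibitor, a lower number a stronger inhibitor), at 247 nM. Its nearest neighbour is compound 1 `CN(C)CCNC(=O)Nc1cc2c(Nc3ccc(F)c(Cl)c3)ncnc2cc1O[C@H]1CCOC1`, which in this assay gives 806 nM, and the step of a 3.3-fold lower number from compound 1 to compound 2 (0.51 log units; beyond the scatter) shows that the group at the end of the urea side chain matters. Compound 3 `COC(CCNC(=O)Nc1cc2c(Nc3ccc(F)c(Cl)c3)ncnc2cc1O[C@H]1CCOC1)OC` differs from compound 2 by dimethoxymethyl in place of pyrrolidin-1-yl on a saturated chain carbon, two bonds along the chain from an amide-type nitrogen. Within the data shown here, only that one measured step bears on this change, and it compares two groups that both bear a nitrogen, whereas the entering dimethoxymethyl bears oxygen and no nitrogen. Among the measured compounds shown here, no measured compound shows how such a group behaves here, so the direction rests on the single observation that this position is sensitive. Compound 3 is therefore expected to give a somewhat higher number in this assay, estimated at 800 nM within 250 nM to 3000 nM, a step of a 3.2-fold higher number from compound 2 to compound 3 (0.51 log units; beyond the scatter).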

Compound 3, half-maximal inhibitory concentration: 22000 nM
Beside the measured number, compound 3's estimate is 28-fold (1.44 log units) below it; the measured number lies above the stated range.
By their numbers in this assay, from the lowest: compound 2; then compound 1; then compound 3.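

In this assay, the change to dimethoxymethyl weighs far more than the exchange between the two amines: the step is an 89-fold higher number from compound 2 to compound 3 (1.95 log units; beyond the scatter), and measured against the dimethylamino side chain it is a 27-fold higher number from compound 1 to compound 3 (1.44 log units; beyond the scatter). The earlier pair showed only that this position responds to which nitrogen group ends the chain, whereas compound 1 and compound 2, which both bear nitrogen there, now stand well apart from compound 3, which bears oxygen and no nitrogen there. Nothing available here accounts for this drop.

With a single group lacking nitrogen, the compounds shown leave open whether the result follows the loss of the amine nitrogen or the dimethoxymethyl group itself. A cyclopentyl group, a morpholin-4-yl group or a carboxylic acid at the end of the same chain would help separate these two readings.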